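The source may hold more compounds than are shown below. What is called first, only, known or untested is meant among the compounds shown, and "the series" means these compounds.

The three measured compounds, each with its read-out in a functional assay on the whole organism (strain albino) with Rattus norvegicus as the target, in the maximal electroshock model, with a stated time of 1 h, at a dose of 30 mg/kg by the intraperitoneal route; a lower number here means less inhibition, a higher number more inhibition at the dose given (going by the name of the read-out):

Compound 1, `CCOC(=O)CNn1c(C)nc2ccc(Br)cc2c1=O`, gives 20%.
Compound 2, `COc1cccc(C2SCC(=O)N2c2nnc(CNn3c(C)nc4ccc(Br)cc4c3=O)s2)c1`, gives 60%.
Compound 3, `CCOC(=O)CNn1c(C)nc2ccccc2c1=O`, gives 20%.

Compound 1 and compound 3 share a core and differ in one place only: hydrogen in place of bromo on an aromatic carbon. That single change made a step of no change at the digits printed from compound 1 to compound 3 (within the scatter). Compound 2 is built on a different and larger core than compound 1; how the two cores differ is not broken down here. Its read-out stands above that of compound 1 and above that of compound 3 by a margin beyond the scatter, so among the three measured compounds its number is the highest.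

Compound 4, `COc1cccc(C2SCC(=O)N2c2nnc(CNn3c(C)nc4ccccc4c3=O)s2)c1`, has not yet been measured. It relates to compound 2 just as compound 3 relates to compound 1: hydrogen in place of bromo on an aromatic carbon. The place is the same word for word in both pairs, so this is the same change, now applied to the core of compound 2. If the change acts as it did before, the step from compound 2 to compound 4 is expected to be about no change at the digits printed from compound 2 to compound 4 (within the scatter), because the earlier step was no change at the digits printed from compound 1 to compound 3 (within the scatter). This expectation rests on a single prior instance, made on a core unlike that of compound 2, so it remains tentative. Compound 4 is therefore estimated to give about 60% in this assay, expected to fall between 45% and 75%.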

Compound 4, a percentage reported as inhibition, in the whole organism at one dose (the size of the read-out at that dose, not a potency): 60%
Beside the measured number, compound 4's estimate shows no gap at the digits printed; the range from low to high includes it.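

In this assay, putting hydrogen in place of bromo on the core of compound 2 gave a step of no change at the digits printed from compound 2 to compound 4 (within the scatter). This is the same swap on the same kind of aromatic carbon, and it behaved alike on the smaller core and the larger one, which is what a medicinal chemist means when a change "carries over" from one core to another: the same change on two cores in this assay, no change at the digits printed (within the scatter) from compound 1 to compound 3 and no change at the digits printed (within the scatter) from compound 2 to compound 4, 0 percentage points apart, within the scatter of two such steps
This does not show that bromo is unimportant in general, or that the swap would behave the same way on any other core: the agreement rests on just two pairs of compounds, in a single whole-animal test at one dose, and such a read-out gives the size of the response at that dose, not a potency, leaving open whether a difference would appear at other doses or in other tests, and giving no explanation for the match.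

The compounds shown carry only bromo or hydrogen at this position, and whether a different group there, such as chloro, an amine or a carboxylic acid, would also leave the read-out within the scatter remains open. Also open, as far as these compounds go, is whether the same holds for a group placed elsewhere on the six-membered aromatic ring.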